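Methoxy to Chloro: Expecting Compound 4

This account rests on a few compounds, and the source may have more. Where it says the series, first, only, none or still open, it means among the compounds named here.

Compound 1 `CNC(=O)c1cc(Oc2ccc(/C=C/c3ccccn3)cc2)ccn1` gives 17400 nM in a functional assay on A549 cells (Homo sapiens) for antiproliferative activity, read by CCK-8 assay, with a stated time of 48 h; a higher number here means a weaker inhibitor, a lower number a stronger inhibitor.
Compound 2 `O=C(Nc1ccccc1)c1cc(Oc2ccc(/C=C/c3ccccn3)cc2)ccn1` gives 19100 nM.
Compound 3 `COc1ccc(NC(=O)c2cc(Oc3ccc(/C=C/c4ccccn4)cc3)ccn2)cc1` gives 20000 nM.

Compound 3 shows the highest of these three numbers, yet the steps of a 1.0-fold higher number from compound 2 to compound 3 (0.02 log units; within the scatter) and a 1.1-fold higher number from compound 1 to compound 3 (0.06 log units; within the scatter) both lie within the scatter, so the three compounds cannot be ranked against one another.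

Compound 4 `O=C(Nc1ccc(Cl)cc1)c1cc(Oc2ccc(/C=C/c3ccccn3)cc2)ccn1` differs from compound 3 by chloro in place of methoxy on an aromatic carbon. For the measured compounds named here, the measured steps bear on this only loosely: phenyl in place of methyl a 1.1-fold higher number from compound 1 to compound 2 (0.04 log units; within the scatter) and methoxy in place of hydrogen a 1.0-fold higher number from compound 2 to compound 3 (0.02 log units; within the scatter) each changed nothing beyond the scatter, and no measured pair tests chloro itself. The step of a 1.1-fold lower number from compound 3 to compound 4 (0.02 log units; within the scatter) is therefore expected to stay within the scatter. Compound 4 is estimated at 19000 nM, between 9000 nM and 40000 nM.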

Compound 4, half-maximal inhibitory concentration: 16200 nM
Compound 4: the middle estimate sits 1.2-fold (0.07 log units) above what was measured, and the stated range covers the measured number.
By their numbers in this assay, from the lowest: compounds 4, 1, 2 and 3 (each within the scatter of the next).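

Chloro, a single heavy atom, now joins methoxy and hydrogen on this aromatic carbon. In this assay, replacing methoxy gives a 1.2-fold lower number from compound 3 to compound 4 (0.09 log units; within the scatter) and replacing hydrogen gives a 1.2-fold lower number from compound 2 to compound 4 (0.07 log units; within the scatter) while 4-chlorophenyl in place of methyl on the amide nitrogen gives a 1.1-fold lower number from compound 1 to compound 4 (0.03 log units; within the scatter) so none of these changes moves the number beyond the scatter. No measurement shown offers a reason for this flat result.

As far as these compounds go, whether an amine or a carboxylic acid at this position would shift the number beyond the scatter remains open. So does whether any change elsewhere on the shared core would do so.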